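A few compounds are considered here, and "the series" means these few. Any claim that something is new, unique, unknown or untested is made for them only; others in the source may bear on it.

Measured so far in an ADME assay on HEK293 cells (Homo sapiens) for cytotoxicity, read by MTT assay; a lower number here means a stronger inhibitor, a higher number a weaker inhibitor:
- compound 1 `Cc1cccc(/C=C/C(=O)c2c(O)cc(C)oc2=O)c1`: 100000 nM
- compound 2 `Cc1cc(O)c(C(=O)/C=C/c2ccc(Br)cc2)c(=O)o1`: 100000 nM

In this assay, compound 2 gives 100000 nM, which stands level with compound 1 at 100000 nM. The two results cannot be told apart, even though the two compounds carry different groups on their aromatic ring.

The next compound to test is compound 3 `COc1ccc(/C=C/C(=O)c2c(O)cc(C)oc2=O)cc1`. It differs from compound 2 in one place, with methoxy in place of bromo on an aromatic carbon. That carbon belongs to a six-membered aromatic ring of carbon only and sits para to a large group.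

Among the measured compounds shown here, no pair of measured compounds differs in just one place, so no direct precedent exists for this swap. For the measured compounds named here, the only guide is the matching pair of results for compound 1 and compound 2, so no shift beyond the usual scatter is expected in this assay. The estimated change no change at the digits printed from compound 2 to compound 3 (within the scatter) is therefore no larger than that scatter. Compound 3 is expected to give 100000 nM, with an estimated range of 40000 nM to 200000 nM.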

Compound 3, half-maximal inhibitory concentration: 100000 nM
Estimate against measurement, compound 3: no gap at the digits printed, and the stated range covers the measured number.
By their numbers in this assay, from the lowest: compounds 1, 2 and 3 (each within the scatter of the next).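

In this assay, putting methoxy in place of bromo on an aromatic carbon para to a large group gives no change at the digits printed from compound 2 to compound 3 (within the scatter), and this is the only step shown that changes a single place. At this position, methoxy brings 2 heavy atoms and 1 hydrogen-bond acceptor where bromo had 1 heavy atom and 0 hydrogen-bond acceptors, yet this pair of compounds cannot be told apart by the read-out. No measurement shown here explains this result.

The compounds shown leave open whether an amine, a carboxylic acid or a longer chain on this same carbon would give a different result from bromo or methoxy. They also leave open whether any change at this position can move the number in this assay, or whether changes elsewhere on the shared core would do so.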